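This account rests on a few compounds, and the source may have more. Where it says the series, first, only, none or still open, it means among the compounds named here.

Measured so far:
compound 1, `CCCCN1CCc2nc(C#Cc3ccccc3)sc2C1`, in an assay on HEK293 cells for positive allosteric modulation of metabotropic glutamate receptor 5 (Homo sapiens), read by FLIPR, with a stated time of 1 h (on this read-out lower numbers stand for an effect already at smaller amounts and higher numbers for an effect only at larger amounts of compound), gives 110 nM.
compound 2, `CC(C)S(=O)(=O)N1Cc2nc(C#Cc3ccccc3)sc2C1`, in this assay reaches only a limit of > 10000 nM.

Among the compounds with values here, compound 1 thus stands as the sole numbered value, while the other entry is the limit of > 10000 nM in this assay, at which 1 of the 2 values shown sits. Compound 3, `O=S(=O)(C1CC1)N1CCc2nc(C#Cc3ccccc3)sc2C1`, keeps the core of compound 1 and differs by cyclopropylsulfonyl in place of butyl on an amine nitrogen in a ring. No step between measured compounds is shown, so the move from a plain butyl amine to a sulfonyl-bearing nitrogen is judged from compound 2 alone. The step of a 45-fold higher number from compound 1 to compound 3 (1.66 log units; beyond the scatter) is expected to be large and toward weaker effect. Compound 3 is therefore estimated at 5000 nM, within 700 nM to 30000 nM.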

Compound 3, half-maximal effective concentration: > 10000 nM
Compound 3: a limit, no number; the forecaster's own chance of this, stated with the estimate: 50%; middle value at least 2.0-fold (0.30 log units) from the limit.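

Within the data shown here, on the amine nitrogen in a ring of the shared core, cyclopropylsulfonyl in place of butyl gives an at least 90-fold higher number from compound 1 to compound 3 (1.95 log units; beyond the scatter), the first step read between compounds that differ in one place. This position therefore does not accept every group, and the change is large and toward weaker effect. In this assay the entry for compound 3 is a limit, not a number: the limit of > 10000 nM in this assay, at which 2 of the 3 values shown sit.

The compounds shown leave open whether this loss follows the sulfonyl or the cyclopropyl. They also leave open how a benzyl group, an acetyl group or a longer chain on this nitrogen would read.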